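The source may report more compounds than this note shows. Statements on the series, on what has been measured and on what is new or still open speak of the compounds shown alone.

Among the compounds with values here, in a functional assay on KYSE-450 cells (Homo sapiens) for inhibition, read by MTT assay, with a stated time of 48 h (a lower number here means a stronger inhibitor, a higher number a weaker inhibitor), compound 1 `C/C=C/C(=O)N(Cc1cc(OC)c(OC)c(OC)c1)c1ccc(OC)c(O)c1` gives 9160 nM, the middle of the three numbers measured so far. Compound 2 `COc1ccc(CNc2cc(OC)c(OC)c(OC)c2)cc1Br` reads higher at 39800 nM, and compound 3 `C/C=C/C(=O)N(Cc1ccc(OC)c(N)c1)c1cc(OC)c(OC)c(OC)c1` reads much lower at 310 nM. Both gaps to compound 1 lie beyond the usual scatter of such measurements.

Compound 4 `COc1ccc(N(Cc2cc(OC)c(OC)c(OC)c2)C(=O)CN=[N+]=[N-])cc1O` has not yet been tested in this assay. It keeps the core of compound 1 but carries azidomethyl in place of prop-1-en-1-yl on a carbonyl carbon. Within the data shown here, no two measured compounds differ in only one place, so the data offer no direct precedent for this change. The spread of the three values shows how far numbers can range in this small set, but it does not say how this particular replacement will behave.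

The best available anchor is therefore compound 1 at 9160 nM. The expectation is a small move towards a weaker reading, with no step beyond the scatter. The estimated change is a 1.5-fold higher number from compound 1 to compound 4 (0.18 log units; within the scatter), and the uncertainty around it is wide. For compound 4 the expected value is 14000 nM, with an estimated range from 4000 nM to 45000 nM.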

Compound 4, half-maximal inhibitory concentration: 26100 nM
The estimate for compound 4 lay 1.9-fold (0.27 log units) below the measured number; low and high end bracket the measured number.
By their numbers in this assay, from the lowest: compound 3; then compound 1; then compounds 4 and 2 (each within the scatter of the next).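

In this assay, within the data shown here, the pair compound 1 and compound 4 gives the first reading of a change in one place, and azidomethyl in place of prop-1-en-1-yl on the carbonyl carbon gives a 2.8-fold higher number from compound 1 to compound 4 (0.45 log units; beyond the scatter), a modest step but one beyond the scatter. The earlier compounds shown here could not show this, as no two of them differed in only one place; this pair shows that the group on this carbonyl carbon can shift the reading on the core of compound 1, while the step stays modest for a swap of an all-carbon group with one double bond for a group carrying three nitrogen atoms. Nothing available accounts for the direction or size of this step.

The compounds shown leave open whether the shift follows from losing prop-1-en-1-yl or from bringing in azidomethyl, which a plain methyl, a saturated propyl chain or an aminomethyl group on the same carbonyl carbon could help separate. They also leave open whether the same exchange would read alike on compound 3, which carries prop-1-en-1-yl on its carbonyl carbon but differs from compound 1 elsewhere.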